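Cytotoxicity notes on the series: the step to compound 4

This account rests on a few compounds, and the source may have more. Where it says the series, first, only, none or still open, it means among the compounds named here.

Measured so far:
compound 1 `CCCCCOc1ccc(C(=O)N(C(=S)OCCN2C(=O)c3ccccc3C2=O)c2ccc(F)cc2)cc1` — > 100000 nM, a limit of the assay
compound 2 `O=C1c2ccccc2C(=O)N1CCOC(=S)N(C(=O)c1cccnc1Cl)c1ccc(Br)cc1` — > 100000 nM, a limit of the assay
compound 3 `O=C1c2ccccc2C(=O)N1CCOC(=S)N(C(=O)c1cc(F)ccc1F)c1ccc(Cl)cc1` — 54000 nM

In an ADME assay on MT4 cells (Homo sapiens) for cytotoxicity, read by MTT assay (on this read-out lower numbers stand for higher toxicity in this test and higher numbers for lower toxicity in this test), compound 1 gives > 100000 nM, which is a limit of the assay and not a number. Compound 2 likewise gives > 100000 nM in this assay, again a limit. Within the data shown here, compound 3 is the only compound of the three with a measured number, at 54000 nM; the other two sit at the limit of > 100000 nM in this assay, at which 2 of the 3 values shown sit, so no step between measured compounds can be counted.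

Compound 4 `Cc1cc(C(=O)N(C(=S)OCCN2C(=O)c3ccccc3C2=O)c2ccc(Cl)cc2)ccc1Br` is not yet measured. It differs from compound 3 in one place: 4-bromo-3-methylphenyl in place of 2,5-difluorophenyl on a carbonyl carbon. Nothing measured in this assay tells how a change on that carbonyl carbon moves the read-out, so the step of a 1.1-fold higher number from compound 3 to compound 4 (0.05 log units; within the scatter) is expected to be small, with no direction beyond the scatter. Compound 4 is therefore expected at 60000 nM in this assay, with a range from 25000 nM to 150000 nM.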

Compound 4, half-maximal cytotoxic concentration: 18000 nM
The estimate for compound 4 lay 3.3-fold (0.52 log units) above the measured number, and the stated range ends above it.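

In this assay, replacing 2,5-difluorophenyl with 4-bromo-3-methylphenyl on a carbonyl carbon gives a 3.0-fold lower number from compound 3 to compound 4 (0.48 log units; beyond the scatter) and shows that the group at this place can move the read-out. This modest step is the only one in the series that can be read. The two groups match in heavy-atom count and in their hydrogen-bond donor and acceptor counts, so those counts do not separate compound 3 from compound 4.

On these data alone, whether the lower number follows the bromine, the methyl or the absence of the two fluorines remains open, as does the effect of an aminomethyl group or a carboxylic acid on this phenyl ring. No other steps can be read, because the remaining values are limits of the assay and not numbers: the limit of > 100000 nM in this assay, at which 2 of the 4 values shown sit.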